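A few compounds are considered here, and "the series" means these few. Any claim that something is new, unique, unknown or untested is made for them only; others in the source may bear on it.

Measured compounds:
- compound 1 `ClCc1cccc(Cn2cnc3c(Cl)nc(Cl)nc32)c1`: 750 nM
- compound 2 `Nc1nc(Cl)c2ncn(Cc3cccc(CCl)c3)c2n1`: no numerical result

In a functional assay on RXF 393 cells (Homo sapiens) for cytotoxicity, read by sulforhodamine B assay, with a stated time of 48 h (a lower number here means a stronger inhibitor of growth, a higher number a weaker inhibitor of growth), compound 1 gives 750 nM. In this assay compound 2 is recorded as "not determined" (no result reported); it carries no number, so compound 2 stands nowhere on the scale shown, and no step from it to any other compound can be read.

Compound 3 `ClCc1cccc(Cn2cnc3c(Cl)ncnc32)c1` differs from compound 2 in one place: hydrogen in place of amino on an aromatic carbon. Whether this change moves growth inhibition up or down cannot be judged from the data, since compound 2 contributes no number to compare against. Within the data shown here, the only anchor for compound 3 is compound 1, which shares the core and the chloromethylbenzyl group but carries a chloro where compound 3 carries a hydrogen; no step between compound 1 and compound 3 is recorded either, so any expectation for compound 3 is loose and should be read as an estimate placed near the one measured value of the series rather than as a projected step.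

Compound 3 is expected to fall at about 1500 nM, within a range of 300 nM to 8000 nM.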

Compound 3, concentration for 50% growth inhibition: 2290 nM
Estimate against measurement, compound 3: 1.5-fold (0.18 log units) below, within the range that was stated.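

In this assay, among these compounds, hydrogen in place of chloro on the aromatic carbon between two ring nitrogen atoms gives a 3.1-fold higher number from compound 1 to compound 3 (0.48 log units; beyond the scatter), the first change that can be read as a step. The position therefore responds to substitution, and the step lies beyond the usual scatter, though it is modest in size. The chloro group at this carbon goes with the stronger growth inhibition of this pair, yet it is not needed for a measurable effect, since compound 3 still gives 2290 nM in this assay. Nothing in the data bears on why the number moves.

Steps to or from compound 2 cannot be read, so where amino at this carbon falls relative to chloro and hydrogen remains open. Also open, from the compounds shown here alone, is where a methoxy group or a dimethylamino group at this carbon would fall on the same scale, and whether a hydroxymethyl group in place of the chloromethyl group would change growth inhibition on the core of compound 1.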